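From compound 1 to compound 4: an untested indole exchange

The source may report more compounds than this note shows. Statements on the series, on what has been measured and on what is new or still open speak of the compounds shown alone.

In a functional assay on SW480 cells (Homo sapiens) for antiproliferative activity, with a stated time of 72 h (on this read-out lower numbers stand for stronger inhibition and higher numbers for weaker inhibition), compound 1 (`O=C(COc1ccc(CN2CC=C(c3c[nH]c4cccc(F)c34)CC2)c(F)c1)NO`) gives 5560 nM as the highest of three numbers. Compound 2 (`O=C(COc1ccc(CN2CC=C(c3c[nH]c4cccc(F)c34)CC2)cc1)NO`) gives 2310 nM and compound 3 (`O=C(COc1ccc(C(=O)N2CC=C(c3c[nH]c4cccc(F)c34)CC2)cc1)NO`) gives 1490 nM in the same test. Compound 4 (`Cc1[nH]c2ccccc2c1C1=CCN(Cc2ccc(OCC(=O)NO)cc2F)CC1`) awaits measurement. Its difference from compound 1 is 2-methyl-1H-indol-3-yl in place of 4-fluoro-1H-indol-3-yl on a double-bonded ring carbon and so 2-methyl-1H-indol-3-yl stands in place of 4-fluoro-1H-indol-3-yl on a double-bonded ring carbon. Within the data shown here, the only measured step, a 2.4-fold lower number from compound 1 to compound 2 (0.38 log units; beyond the scatter), is hydrogen in place of fluoro on an aromatic carbon, a different change. Among the measured compounds shown here, no measured compound carries the entering group, so no step beyond the scatter is expected in either direction in this assay here. The expected step is a 1.2-fold lower number from compound 1 to compound 4 (0.09 log units; within the scatter) and no more. Compound 4 is estimated at 4500 nM with a range from 1700 nM to 11000 nM as expected.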

Compound 4, half-maximal inhibitory concentration: 1600 nM
Estimate against measurement, compound 4: 2.8-fold (0.45 log units) above; measured number below the stated range.
By their numbers in this assay, from the lowest: compounds 3, 4 and 2 (each within the scatter of the next); then compound 1.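

In this assay, the exchange of 4-fluoro-1H-indol-3-yl for 2-methyl-1H-indol-3-yl on the double-bonded ring carbon gives a 3.5-fold lower number from compound 1 to compound 4 (0.54 log units; beyond the scatter) and so shows that this position can move the read-out. The earlier compounds shown here all carried 4-fluoro-1H-indol-3-yl, so they showed nothing about this place. Nothing available explains the step.

The compounds shown leave open whether the step follows from gaining the methyl or from losing the fluoro. Plain 1H-indol-3-yl at this place would separate the two.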